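The compounds below may be only part of what the source reports. "The series", "measured", "known", "first", "only" and "open" are said of these compounds alone.

Among the measured compounds shown here, in a functional assay on SGC-7901 cells (Homo sapiens) for inhibition, read by MTT assay, with a stated time of 24 h (a lower number here means a stronger inhibitor, a higher number a weaker inhibitor), compound 1 `CC1(C)[C@H]2CC[C@]1(C)N(Cc1cn(-c3cccc(F)c3)nn1)C(=O)C2` gives 530 nM, the highest of the three numbers measured so far. Compound 2 `CC1(C)[C@H]2CC[C@]1(C)N(Cc1cn(-c3ccccc3)nn1)C(=O)C2` gives 240 nM, and compound 3 `Cc1ccccc1-n1cc(CN2C(=O)C[C@@H]3CC[C@@]2(C)C3(C)C)nn1` gives 350 nM. Compound 4 `COc1cccc(-n2cc(CN3C(=O)C[C@@H]4CC[C@@]3(C)C4(C)C)nn2)c1` has not been measured; it differs from compound 1 by methoxy in place of fluoro on an aromatic carbon. Two measured steps change the same spot on compound 1: a 2.2-fold lower number from compound 1 to compound 2 (0.34 log units; beyond the scatter), and a 1.5-fold lower number from compound 1 to compound 3 (0.18 log units; within the scatter). Both take the fluoro away and neither shifts the number more than modestly, so the change to methoxy is expected to give a step of similar size in this assay, if anything toward a lower number. Compound 4 is therefore estimated at 350 nM, with a range from 150 nM to 800 nM, meaning an expected 1.5-fold lower number from compound 1 to compound 4 (0.18 log units; within the scatter).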

Compound 4, half-maximal inhibitory concentration: 590 nM
Compound 4: the middle estimate sits 1.7-fold (0.23 log units) below what was measured; low and high end bracket the measured number.
By their numbers in this assay, from the lowest: compounds 2, 3, 1 and 4 (each within the scatter of the next, the first and the last beyond it).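

In this assay, putting methoxy where fluoro stood gives a 1.1-fold higher number from compound 1 to compound 4 (0.05 log units; within the scatter), so the two groups cannot be told apart at this place. Methoxy, like fluoro, gives a number clearly separate from that with plain hydrogen, with a 2.5-fold higher number from compound 2 to compound 4 (0.39 log units; beyond the scatter), whereas a 1.7-fold higher number from compound 3 to compound 4 (0.23 log units; within the scatter) leaves it unseparated from the 2-methylphenyl compound. Nothing available here explains these numbers. Still open, as far as these compounds go, is how an amine or a carboxylic acid at this same place on the ring would behave, and whether any group there gives a lower number than hydrogen.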